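The source may report more compounds than this note shows. Statements on the series, on what has been measured and on what is new or still open speak of the compounds shown alone.

Compound 2 `O=S(=O)(c1ccc(F)c(F)c1)N1CCCC(Cn2ccnc2)C1` gives 43 nM in an assay on isolated protein for inhibition of Aromatase (Homo sapiens), read by fluorescence (on this read-out lower numbers stand for stronger inhibition and higher numbers for weaker inhibition), the higher of the two numbers measured; compound 1 `COc1ccc(S(=O)(=O)N2CCCC(Cn3ccnc3)C2)cc1F` gives 14 nM. Within the data shown here, the one measured step, a 3.1-fold higher number from compound 1 to compound 2 (0.49 log units; beyond the scatter), concerns a fluoro replacing a methoxy rather than a fluoro replacing a hydrogen, so it bears on the present change only loosely. Compound 3 `O=S(=O)(c1ccc(F)c(F)c1F)N1CCCC(Cn2ccnc2)C1` differs from compound 2 by fluoro in place of hydrogen on an aromatic carbon, placed ortho to a fluoro group, ortho to a large group and meta to a fluoro group. Among the measured compounds shown here, with no closer step to lean on, no change beyond the scatter is expected, and compound 3 is estimated at 50 nM (range 20 nM to 130 nM), a step of a 1.2-fold higher number from compound 2 to compound 3 (0.07 log units; within the scatter) in this assay.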

Compound 3, half-maximal inhibitory concentration: 46 nM
Estimate against measurement, compound 3: 1.1-fold (0.04 log units) above; the range from low to high includes it.
By their numbers in this assay, from the lowest: compound 1; then compounds 2 and 3 (each within the scatter of the next).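

In this assay, fluoro in place of hydrogen, ortho to a fluoro group and ortho to a large group, gives a 1.1-fold higher number from compound 2 to compound 3 (0.03 log units; within the scatter), so this position accepts a fluoro with no change beyond the scatter. The earlier step concerned fluoro replacing methoxy and gave no reading on hydrogen replaced at this position. Nothing at hand accounts for this flat step. The compounds shown carry only hydrogen or fluoro here. On these data alone, whether an amine or a carboxylic acid at this position would leave the number equally unchanged remains open.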